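From methyl to 1,1-difluoroethyl: expected removal of compound 3

A few compounds are considered here, and "the series" means these few. Any claim that something is new, unique, unknown or untested is made for them only; others in the source may bear on it.

- compound 1 `CC1SC(c2cccc(C(=O)NCCCCc3ccccc3)c2)N(c2ccc(C3CC3)cc2)C1=O` gives 3130 mL.min-1.g-1
- compound 2 `Cc1cccc(N2C(=O)CSC2c2cccc(C(=O)NCCCCc3ccccc3)c2)c1` gives 3140 mL.min-1.g-1

In an ADME assay on microsomes from liver (Rattus norvegicus) for metabolic stability, read by LC-MS, using NADPH, with a stated time of 10 min, tested at 0.1 uM (a higher number here means faster removal of the compound, a lower number slower removal), compound 2 stands level with compound 1, as their gap lies within the usual scatter of repeat measurements. Compound 3 `CC(F)(F)c1cccc(N2C(=O)CSC2c2cccc(C(=O)NCCCCc3ccccc3)c2)c1` carries one change from compound 2: 1,1-difluoroethyl in place of methyl on an aromatic carbon. Among the compounds with values here, no measured pair shows what such a swap does, so the size of the step remains uncertain. The starting point is compound 2 at 3140 mL.min-1.g-1, and only a small downward shift, not beyond the scatter, is expected. The estimated change is a 1.1-fold lower number from compound 2 to compound 3 (0.05 log units; within the scatter). For compound 3, the expected value is 2800 mL.min-1.g-1, with an estimated range of 1300 mL.min-1.g-1 to 5500 mL.min-1.g-1.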

Compound 3, intrinsic clearance in microsomes: 2320 mL.min-1.g-1
For compound 3 the middle estimate is 1.2-fold (0.08 log units) above the measured one, and the stated range covers the measured number.
By their numbers in this assay, from the lowest: compounds 3, 1 and 2 (each within the scatter of the next).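

In this assay, within the data shown here, the first measured swap at this position, 1,1-difluoroethyl in place of methyl on an aromatic carbon, gives a 1.4-fold lower number from compound 2 to compound 3 (0.13 log units; within the scatter) and stays within the usual scatter. At this place, meta to a large group, the larger group with two fluorine atoms therefore leaves removal without a clear shift. Nothing measured here points to an explanation for this result. As far as these compounds go, whether an amine, a carboxylic acid or a longer chain at this position would move removal beyond the scatter remains open.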